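A few compounds are considered here, and "the series" means these few. Any claim that something is new, unique, unknown or untested is made for them only; others in the source may bear on it.

Compound 1, `O=C(O)c1cccc(OCc2ccccc2)c1O`, in an ADME assay on NCI-H630 cells (Homo sapiens) for cytotoxicity, read by MTT assay, with a stated time of 72 h (a higher number here means that more compound is tolerated, a lower number that less compound is tolerated), gives > 40000 nM, which is a limit of the assay rather than a number.
Compound 2, `O=C(O)c1cccc(OCc2ccc3ccccc3c2)c1O`, in this assay gives > 40000 nM, again a limit of the assay.
Compound 3, `O=C(O)c1ccc(OCc2ccccc2)cc1O`, in this assay gives > 40000 nM, also a limit of the assay.

All three values sit at the limit of > 40000 nM in this assay, at which 3 of the 3 values shown sit, so compound 3 stands at the same limit as the other two and cannot be told apart from them on these numbers. Compound 4, `O=C(O)c1ccc(OCc2ccc(F)cc2)cc1O`, has not yet been measured in this assay. It differs from compound 3 by fluoro in place of hydrogen on an aromatic carbon, para to a large group. For the measured compounds named here, no step between measured compounds is recorded, so there is no measured guide to the size of this change. Given that every measured compound sits at the limit, the step that the limit leaves unreadable from compound 3 to compound 4 is expected to be none beyond the scatter. Compound 4 is therefore expected to give 50000 nM in this assay, within a range from 20000 nM to 200000 nM.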

Compound 4, half-maximal cytotoxic concentration: > 40000 nM
Compound 4 gave a limit, no number; the forecaster's own chance of this, stated with the estimate: 85%; the middle value is on the limit's open side.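

No step can be read from compound 3 to compound 4, because both give only a limit, and it is the same one: the limit of > 40000 nM in this assay, at which 4 of the 4 values shown sit 
The compounds shown leave open how far each true value lies past that limit, and whether any change to the shared core would bring a value into measurable range.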